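Removing a methyl from an aryl methoxy group

The source may report more compounds than this note shows. Statements on the series, on what has been measured and on what is new or still open speak of the compounds shown alone.

Compound 1 `COc1cc(O)c(C(=O)/C=C/c2ccccc2SC)c(OC)c1` gives > 20000 nM in an ADME assay on cells (Fibroblast, Homo sapiens) for cytotoxicity, with a stated time of 48 h (a lower number here means a stronger inhibitor, a higher number a weaker inhibitor), which is a limit of the assay rather than a number.
Compound 2 `COc1cc(OC)c(C(=O)/C=C/c2ccccc2OC)c(OC)c1` gives 8200 nM in this assay.

For the measured compounds named here, compound 2 thus holds the only measured number here, while the other value shown sits at the limit of > 20000 nM in this assay, at which 1 of the 2 values shown sits. Going by the values given here, no two measured compounds differ in a single place, so no measured step is available to calibrate the change under study.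

Compound 3 `COc1cc(O)c(C(=O)/C=C/c2ccccc2OC)c(OC)c1` differs from compound 2 by hydrogen in place of methyl on an oxygen on an aromatic ring. Compound 1 also carries a hydroxy group on its core and differs from compound 2 in two places, so its value says nothing firm about this single change. With that in mind, the step from compound 2 to compound 3 is expected to be modest and toward weaker cytotoxicity, a 1.8-fold higher number from compound 2 to compound 3 (0.26 log units; within the scatter). Compound 3 is therefore estimated at 15000 nM, with a range from 5000 nM to 40000 nM.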

Compound 3, half-maximal inhibitory concentration: > 20000 nM
Compound 3: only a limit was reported; the forecaster's own chance of this, stated with the estimate: 40%; middle value at least 1.3-fold (0.12 log units) from the limit.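

The change from methoxy to hydroxy now has a measured size in this assay, with an at least 2.4-fold higher number from compound 2 to compound 3 (0.38 log units; beyond the scatter). Removing this one methyl from an oxygen on an aromatic ring therefore weakens cytotoxicity beyond the usual scatter, something compound 1 could not show because it differs from compound 2 in two places. The swap of methylsulfanyl for methoxy, however, cannot be read, and the true size of the methyl step also stays hidden, because the values for compound 1 and compound 3 are both limits: the limit of > 20000 nM in this assay, at which 2 of the 3 values shown sit.

From the compounds shown here alone, it remains open how far the number for compound 3 lies past that limit. Also open, going by these compounds, is how an ethyl group, or a longer chain ending in an amine, on this same oxygen would compare with the methyl and the hydrogen.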